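A few compounds are considered here, and "the series" means these few. Any claim that something is new, unique, unknown or untested is made for them only; others in the source may bear on it.

Compound 1 `CCN(CC)Cc1cccc(Nc2nc3ccccc3n2Cc2ccc(C#N)cc2)c1O` gives > 50000 nM (a limit)
Compound 2 `CCN(CC)Cc1cccc(Nc2nc3ccccc3n2Cc2ccc(F)cc2)c1O` gives > 50000 nM (a limit)
Compound 3 `CCN(CC)Cc1ccc(C)c(Nc2nc3ccccc3n2Cc2ccc(C#N)cc2)c1O` gives > 50000 nM (a limit)

In an ADME assay on CHO cells (Cricetulus griseus) for inhibition, read by MTT assay (a higher number here means a weaker inhibitor, a lower number a stronger inhibitor), compound 3 stands at > 50000 nM, which is a limit of the assay and not a number. The whole set so far sits at one ceiling: the limit of > 50000 nM in this assay, at which 3 of the 3 values shown sit. Compound 4 `CCN(CC)Cc1ccc(C)c(Nc2nc3ccccc3n2Cc2ccc(F)cc2)c1O` differs from compound 3 as follows: fluoro in place of cyano on an aromatic carbon. Among the measured compounds shown here, the same swap of fluoro in place of cyano appears in a step that the two limits leave unreadable from compound 1 to compound 2, the closest precedent. The other measured change, methyl in place of hydrogen, is a step that the two limits leave unreadable from compound 1 to compound 3. Neither offers a size or direction to carry over, so no step beyond the scatter is expected in this assay. The expected result is a number no higher from compound 3 to compound 4 (the limit leaves the size open), most likely another limit. Compound 4 is estimated at 50000 nM, with an expected range from 20000 nM to 100000 nM.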

Compound 4, half-maximal inhibitory concentration: > 50000 nM
Compound 4: no number, only a limit; the forecaster's own chance of this, stated with the estimate: 80%; the middle value sits exactly at the limit.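

Compound 4 also gives only a limit, so neither its step from compound 3 nor its step from compound 2 can be read: the limit of > 50000 nM in this assay, at which 4 of the 4 values shown sit. On these data alone, whether swapping cyano for fluoro or adding the methyl changes inhibition at all in this assay stays open.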